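Fluoro for methoxy on the cinnamate ring of compound 3

The compounds below may be only part of what the source reports. "The series", "measured", "known", "first", "only" and "open" are said of these compounds alone.

Among the compounds with values here, compound 3 `COc1ccc(/C=C/C(=O)Oc2ccc(/C=C3\CCCC(CN(C)C)C3=O)cc2)cc1` stands lowest of the two numbers so far in a functional assay on P388 cells (Mus musculus) (on this read-out lower numbers stand for stronger inhibition and higher numbers for weaker inhibition), where compound 3 gives 2410 nM. Its nearest neighbour is compound 2 `CN(C)CC1CCC/C(=C\c2ccc(OC(=O)/C=C/c3ccccc3)cc2)C1=O`, which in this assay gives 4020 nM; the step of a 1.7-fold lower number from compound 2 to compound 3 (0.22 log units; within the scatter) is within the scatter. Compound 1 `O=C(/C=C/c1ccc(F)cc1)Oc1ccc(/C=C2\CCCCC2=O)cc1` is reported in this assay only as a limit, > 50000 nM; it is noted here as the limit of > 50000 nM in this assay, at which 1 of the 3 values shown sits, and lacks the dimethylaminomethyl group, so it does not inform the present step directly.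

Compound 4 `CN(C)CC1CCC/C(=C\c2ccc(OC(=O)/C=C/c3ccc(F)cc3)cc2)C1=O` differs from compound 3 by fluoro in place of methoxy on an aromatic carbon. Within the data shown here, the only measured step that bears on this position, a 1.7-fold lower number from compound 2 to compound 3 (0.22 log units; within the scatter), was within the scatter, so a change at the same site is not expected to move the number beyond the scatter in either direction. The step of a 1.5-fold higher number from compound 3 to compound 4 (0.16 log units; within the scatter) is therefore estimated to stay within the scatter. For compound 4 in this assay a value of 3500 nM is expected, ranging from 1200 nM to 10000 nM.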

Compound 4, half-maximal inhibitory concentration: 4550 nM
Estimate against measurement, compound 4: 1.3-fold (0.11 log units) below, within the range that was stated.
By their numbers in this assay, from the lowest: compounds 3, 2 and 4 (each within the scatter of the next). At a limit, above all of these: compound 1.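

In this assay, the change from 4-methoxyphenyl to 4-fluorophenyl gives a 1.9-fold higher number from compound 3 to compound 4 (0.28 log units; within the scatter), and fluoro in place of hydrogen on the same aromatic carbon gives a 1.1-fold higher number from compound 2 to compound 4 (0.05 log units; within the scatter). Hydrogen, methoxy and fluoro at this position therefore all lie within the scatter of one another, so none of the three can be ranked above the others. The only step beyond the scatter lies elsewhere, at the saturated ring carbon, where (dimethylamino)methyl in place of hydrogen gives an at least 10-fold lower number from compound 1 to compound 4 (1.04 log units; beyond the scatter), and this step starts from a value that is a limit and not a number: the limit of > 50000 nM in this assay, at which 1 of the 4 values shown sits.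

From the compounds shown here alone, what an amine or a carboxylic acid on this aromatic carbon would give remains open. Also open, going by these compounds, is whether a longer chain carrying the dimethylamino group would hold the number seen for compound 4.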